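Amide Variation at the Aryl Carbonyl and Maximal Response

The source may report more compounds than this note shows. Statements on the series, on what has been measured and on what is new or still open speak of the compounds shown alone.

Compound 3 `CC#C[C@@H](CC(=O)O)c1ccc(OC[C@H]2COc3ccc(C(=O)N(C)C)cc3O2)cc1` gives 32% in a functional assay on HEK293 cells for agonist activity at Free fatty acid receptor 1 (Homo sapiens), read by fluorescence and calcium flux, with a stated time of 10 min (a higher number here means a larger maximal response, a lower number a smaller maximal response), and stands lowest of the three measured numbers. Compound 1 `CC#C[C@@H](CC(=O)O)c1ccc(OC[C@H]2COc3ccc(C#N)cc3O2)cc1` gives 60% in this assay, and compound 2 `CC#C[C@@H](CC(=O)O)c1ccc(OC[C@H]2COc3ccc(C(C)=O)cc3O2)cc1` gives 51%. The measured steps are a number 9 percentage points lower from compound 1 to compound 2 (within the scatter), a number 28 percentage points lower from compound 1 to compound 3 (beyond the scatter) and a number 19 percentage points lower from compound 2 to compound 3 (beyond the scatter).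

Compound 4 `CC#C[C@@H](CC(=O)O)c1ccc(OC[C@H]2COc3ccc(C(=O)N4CCOCC4)cc3O2)cc1` differs from compound 3 by morpholin-4-yl in place of dimethylamino on a carbonyl carbon. Among the compounds with values here, no measured step changes the amine part of the amide itself; the only step that touches the carbonyl carbon is a number 19 percentage points lower from compound 2 to compound 3 (beyond the scatter), where the dimethylamino group replaced a methyl. Compound 3 and compound 4 both carry an amide at this position, so the present step is expected to be smaller than that one and to stay within the scatter, with a slight lean downward given that compound 3 already sits at the low end. Compound 4 is therefore estimated at 28%, within 16% to 40%, which is expected to amount to a number 4 percentage points lower from compound 3 to compound 4 (within the scatter).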

Compound 4, largest response reached (Emax), in percent of the reference or control that the assay uses: 33%
The estimate for compound 4 lay 5 percentage points below the measured number, within the range that was stated.
By their numbers in this assay, from the lowest: compounds 3 and 4 (each within the scatter of the next); then compounds 2 and 1 (each within the scatter of the next).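

Changing the amine part of the amide from dimethylamino to morpholin-4-yl, which adds a six-membered ring and a hydrogen-bond acceptor, gives no difference that can be told apart in this assay (a number 1 percentage points higher from compound 3 to compound 4 (within the scatter)). The lower maximal response seen for the dimethylamide therefore also holds for this second, larger amide, both against the acetyl compound (a number 18 percentage points lower from compound 2 to compound 4 (beyond the scatter)) and against the cyano compound (a number 27 percentage points lower from compound 1 to compound 4 (beyond the scatter)). Nothing at hand explains these numbers.

The compounds shown leave open whether a piperidin-1-yl group on the same carbonyl carbon, which has no ring oxygen, would read like these two amides. They also leave open whether a methylamino group, which keeps the amide hydrogen, would stay at this level or come closer to the cyano compound.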